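Swapping an Acetyl for a Carbamoyl on the Core

This account rests on a few compounds, and the source may have more. Where it says the series, first, only, none or still open, it means among the compounds named here.

Measured compounds in a functional assay for antagonist activity at C-X-C chemokine receptor type 3 (Homo sapiens); on this read-out lower numbers stand for stronger inhibition and higher numbers for weaker inhibition:
compound 1 `CNC(=O)c1cnc(N2CCN(C3CCN(Cc4ccc(Cl)cc4)CC3)[C@@H](C)C2)c(Cl)c1` gives 32 nM;
compound 2 `CNC(=O)c1cnc(N2CCN(C3CCN(Cc4ccc(Cl)cc4F)CC3)[C@@H](C)C2)c(Cl)c1` gives 18 nM;
compound 3 `CC(=O)c1cnc(N2CCN(C3CCN(Cc4ccc(Cl)cc4)CC3)[C@@H](C)C2)c(Cl)c1` gives 520 nM.

Compound 3 stands highest of the three, that is, it is the weakest blocker here. Within the data shown here, its step from compound 1, a 16-fold higher number from compound 1 to compound 3 (1.21 log units; beyond the scatter), is the only large change seen, and it comes from a methyl replacing a methylamino on the carbonyl carbon. The step of a 1.8-fold lower number from compound 1 to compound 2 (0.25 log units; within the scatter), a fluoro on an aromatic carbon, stays within the scatter.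

Compound 4 `C[C@H]1CN(c2ncc(C(N)=O)cc2Cl)CCN1C1CCN(Cc2ccc(Cl)cc2)CC1` is the next compound. Among the measured compounds shown here, its change from compound 3 is amino in place of methyl on a carbonyl carbon, so the acetyl becomes a carbamoyl, restoring an amide like the one in compound 1, though now without the methyl on the nitrogen. Because a 16-fold higher number from compound 1 to compound 3 (1.21 log units; beyond the scatter) shows how much was lost when the amide was removed, a comparable gain is expected on putting one back, giving an expected step of a 13-fold lower number from compound 3 to compound 4 (1.11 log units; beyond the scatter) in this assay. Compound 4 is therefore estimated at 40 nM, likely between 15 nM and 120 nM.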

Compound 4, half-maximal inhibitory concentration: 39 nM
Estimate against measurement, compound 4: 1.0-fold (0.01 log units) above, and the stated range covers the measured number.
By their numbers in this assay, from the lowest: compounds 2, 1 and 4 (each within the scatter of the next, the first and the last beyond it); then compound 3.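

In this assay the step of a 13-fold lower number from compound 3 to compound 4 (1.12 log units; beyond the scatter) shows that at this carbonyl carbon an amino group alone, with no methyl on its nitrogen, is enough to bring back the lost inhibition. The step of a 1.2-fold higher number from compound 1 to compound 4 (0.09 log units; within the scatter) shows that the methyl on the amide-type nitrogen of compound 1 can go without a change beyond the scatter, so among these compounds the large difference follows the nitrogen on the carbonyl carbon and not that methyl. Nothing measured here explains why this nitrogen matters so much.

Still open, going by these compounds, is how other groups on this carbonyl carbon would compare, such as the hydroxyl of a carboxylic acid, the methoxy of a methyl ester, or a longer chain such as ethylamino. Also open, on these data alone, is whether the fluoro change seen in compound 2 would behave the same way on the carbamoyl of compound 4.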